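Removing one chloro from compound 3

This account rests on a few compounds, and the source may have more. Where it says the series, first, only, none or still open, it means among the compounds named here.

In a functional assay on CEM-SS cells (Homo sapiens) for cytotoxicity (on this read-out higher numbers stand for weaker inhibition and lower numbers for stronger inhibition), compound 3 `Clc1ccc(Cn2c(Cl)nc3cc(Cl)c(Cl)cc32)cc1Cl` gives > 100000 nM as a limit of the assay, not a number. Compound 4 `Clc1cccc(Cn2c(Cl)nc3cc(Cl)c(Cl)cc32)c1` carries hydrogen in place of chloro on an aromatic carbon, ortho to a chloro group and para to a large group, and hydrogen in place of chloro on an aromatic carbon is the whole change. The same swap links compound 1 `Nc1nc2cc(Cl)c(Cl)cc2n1Cc1ccc(Cl)c(Cl)c1` at 30000 nM with compound 2 `Nc1nc2cc(Cl)c(Cl)cc2n1Cc1cccc(Cl)c1` at 37000 nM among the amino compounds. There it gave a 1.2-fold higher number from compound 1 to compound 2 (0.09 log units; within the scatter) and that single step is the reason no step beyond the scatter is expected in this assay here. The other measured step, chloro in place of amino, gave an at least 3.3-fold higher number from compound 1 to compound 3 (0.52 log units; beyond the scatter) and concerns a different place. The expected step is a step that the limit leaves unreadable from compound 3 to compound 4 on this estimate. The estimate for compound 4 is 110000 nM with an expected range from 50000 nM to 250000 nM.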

Compound 4, half-maximal inhibitory concentration: > 100000 nM
Compound 4: no number, only a limit; the forecaster's own chance of this, stated with the estimate: 70%; the middle value is on the limit's open side.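

In this assay, the change from amino to chloro now also holds on the core with one chloro fewer on the aromatic ring, with an at least 2.7-fold higher number from compound 2 to compound 4 (0.43 log units; beyond the scatter). The change thus points the same way on both cores shown: the same change on two cores in this assay, an at least 3.3-fold higher number (0.52 log units; beyond the scatter) from compound 1 to compound 3 and an at least 2.7-fold higher number (0.43 log units; beyond the scatter) from compound 2 to compound 4; the limit leaves it open whether they differ. The step from removing that ring chloro cannot be read, since compound 3 and compound 4 both stand at a limit rather than a number: the limit of > 100000 nM in this assay, at which 2 of the 4 values shown sit. Going by these compounds, whether a methyl group, a hydroxyl group or a carboxylic acid in place of the amino group would give a readable number stays open.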